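Compound 3 loses its chloro groups

The compounds below may be only part of what the source reports. "The series", "measured", "known", "first", "only" and "open" are said of these compounds alone.

Compounds measured in a functional assay on U-87MG ATCC cells (Homo sapiens) for inhibition (on this read-out lower numbers stand for stronger inhibition and higher numbers for weaker inhibition), are these.
Compound 1 `COc1cc(/C=C/C(=O)c2cccc(NC(=O)c3cc(Cl)cc(Cl)c3)c2)ccc1O` gives > 50 ug/mL as a limit
Compound 2 `COc1cc(/C=C/C(=O)c2cccc(NC(=O)c3ccc(Cl)cc3)c2)ccc1O` gives > 50 ug/mL as a limit
Compound 3 `COc1cc(/C=C/C(=O)c2cccc(NC(=O)c3ccc(Cl)c(Cl)c3)c2)ccc1O` gives 29.5 ug/mL as a number

Compound 3 alone gives a number. The others stand at the limit of > 50 ug/mL in this assay, at which 2 of the 3 values shown sit, and can be read only as limits. Compound 4 `COc1cc(/C=C/C(=O)c2cccc(NC(=O)c3ccccc3)c2)ccc1O` differs from compound 3 by phenyl in place of 3,4-dichlorophenyl on a carbonyl carbon and has phenyl in place of 3,4-dichlorophenyl on a carbonyl carbon. The closest measured change is chloro in place of hydrogen on an aromatic carbon, seen in an at least 1.6-fold lower number from compound 2 to compound 3 (0.22 log units; that floor lies within the scatter) and supported by the related at least 1.6-fold lower number from compound 1 to compound 3 (0.22 log units; that floor lies within the scatter) as a second floor. Both steps point the same way, so a higher number is expected in this assay without a readable size. The estimate for compound 4 is 60 ug/mL with an expected range from 30 ug/mL to 120 ug/mL as its ends. What is expected is a 2.0-fold higher number from compound 3 to compound 4 (0.31 log units; beyond the scatter) and a reading at the limit is likely.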

Compound 4, half-maximal inhibitory concentration: 8.82 ug/mL
For compound 4 the middle estimate is 6.8-fold (0.83 log units) above the measured one, and the stated range ends above it.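

On the carbonyl carbon, the unsubstituted phenyl of compound 4 gives the lowest number shown in this assay, so chloro on this ring is not needed for inhibition here, with a 3.3-fold lower number from compound 3 to compound 4 (0.52 log units; beyond the scatter). Against the other chlorinated compounds, the same comparison gives an at least 5.6-fold lower number from compound 2 to compound 4 (0.75 log units; beyond the scatter) and an at least 5.6-fold lower number from compound 1 to compound 4 (0.75 log units; beyond the scatter). These two steps are only floors, because compound 1 and compound 2 stand at a limit: the limit of > 50 ug/mL in this assay, at which 2 of the 4 values shown sit.

As far as these compounds go, it remains open how a methoxy group, an amine or a carboxylic acid on this phenyl would read, and whether any group there would give a lower number than compound 4.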